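A few compounds are considered here, and "the series" means these few. Any claim that something is new, unique, unknown or untested is made for them only; others in the source may bear on it.

Measured compounds:
compound 1, `O=C(CSc1nnnn1-c1ccccc1)N/N=c1/scc(-c2ccc(Br)cc2)n1-c1ccccc1`: 32%
compound 2, `O=C(CSc1nnnn1-c1ccccc1)N/N=c1/scc(-c2ccc(F)cc2)n1-c1ccccc1`: 43.7%

Both were tested in a functional assay on C6 cells (Rattus norvegicus) for cytotoxicity, read by MTT assay, with a stated time of 24 h, tested at 50 ug/mL; a lower number here means a stronger effect, a higher number a weaker effect of the compound at the concentration tested. Compound 2 stands highest of the two numbers; its nearest neighbour is compound 1, and the step of a number 11.7 percentage points higher from compound 1 to compound 2 (beyond the scatter) lies beyond the scatter. Compound 3, `O=C(CSc1nnnn1-c1ccccc1)N/N=c1/scc(-c2ccccc2)n1-c1ccccc1`, has not yet been measured in this assay. It differs from compound 2 in one place: hydrogen in place of fluoro on an aromatic carbon.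

Within the data shown here, only one measured step exists, and it does not repeat this change: it exchanges one halogen for another rather than removing one. Among the measured compounds shown here, still, it is the only guide available, and it was modest, the number rising from compound 1 to compound 2 by a number 11.7 percentage points higher from compound 1 to compound 2 (beyond the scatter). Taking the loss of the remaining halogen as a further move of similar kind, a modest rise of the number in this assay is expected, though it may fall within the scatter. Compound 3 is therefore estimated at 52%, within a range from 38% to 66%, which corresponds to an expected step of a number 8.3 percentage points higher from compound 2 to compound 3 (within the scatter).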

Compound 3, a percentage reported as activity, at one concentration (the size of the read-out at that concentration, not a potency): 36.7%
The estimate for compound 3 lay 15.3 percentage points above the measured number; the measured number lies below the stated range.
By their numbers in this assay, from the lowest: compounds 1, 3 and 2 (each within the scatter of the next, the first and the last beyond it).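

In this assay, hydrogen in place of fluoro gives a number 7 percentage points lower from compound 2 to compound 3 (within the scatter), and hydrogen in place of bromo on the same aromatic carbon gives a number 4.7 percentage points higher from compound 1 to compound 3 (within the scatter), so the compound without a halogen cannot be told apart from either halogen compound. Among these compounds, the only step at this position that lies beyond the scatter is still the exchange of one halogen for the other, a number 11.7 percentage points higher from compound 1 to compound 2 (beyond the scatter), and these three compounds therefore form no series in which removing the halogen carries the number further in the direction of that step. No measurement is available that would account for these numbers.

The compounds shown leave open whether a different kind of group at this position, such as a methoxy group, an amine or a carboxylic acid, would separate itself from the phenyl compound by more than the scatter. They also leave open whether the gap between the bromo and fluoro compounds would hold at other concentrations, since each number here is a read-out at a single concentration and not a potency.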